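The compounds below may be only part of what the source reports. "The series", "measured", "known", "first", "only" and "open" are said of these compounds alone.

Three measured compounds share one core. Compound 1 `CC(C)=CC[C@@H](OC[C@H](C)O)C1=CC(=O)c2c(O)ccc(O)c2C1=O` gives 40300 nM in a functional assay on HeLa cells (Homo sapiens) for cytotoxicity, read by MTT assay; on this read-out lower numbers stand for stronger inhibition and higher numbers for weaker inhibition. Compound 2 `CC(C)=CC[C@@H](OC[C@@H](C)O)C1=CC(=O)c2c(O)ccc(O)c2C1=O` gives 22500 nM, and compound 3 `CC[C@](C)(O)CC(=O)O[C@H](CC=C(C)C)C1=CC(=O)c2c(O)ccc(O)c2C1=O` gives 30200 nM. Compound 2 thus holds the lowest of the three numbers, though its gaps to both others lie within the scatter. The unmeasured compound 4 `CC(C)=CC[C@@H](OC(=O)C1CCOC1)C1=CC(=O)c2c(O)ccc(O)c2C1=O` differs from compound 2 in one place: (oxolan-3-yl)carbonyl in place of 2-hydroxypropyl on an oxygen on a saturated carbon. The closest measured step also replaced 2-hydroxypropyl by a carbonyl-linked group on an oxygen on a saturated carbon and read a 1.3-fold higher number from compound 2 to compound 3 (0.13 log units; within the scatter), while the change of configuration alone read a 1.8-fold lower number from compound 1 to compound 2 (0.25 log units; within the scatter). Neither moved the number beyond the scatter, so for compound 4 a step of a 1.2-fold higher number from compound 2 to compound 4 (0.06 log units; within the scatter) is expected, and its value is estimated at 26000 nM, most likely between 11000 nM and 60000 nM.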

Compound 4, half-maximal inhibitory concentration: 73500 nM
Estimate against measurement, compound 4: 2.8-fold (0.45 log units) below, outside the stated range (above it).
By their numbers in this assay, from the lowest: compounds 2, 3, 1 and 4 (each within the scatter of the next, the first and the last beyond it).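

Among the compounds shown here, the (oxolan-3-yl)carbonyl group is the first change at this oxygen to move the number beyond the scatter (a 3.3-fold higher number from compound 2 to compound 4 (0.51 log units; beyond the scatter)), and swapping the group on the carbonyl carbon does so too (a 2.4-fold higher number from compound 3 to compound 4 (0.39 log units; beyond the scatter)). A carbonyl link alone therefore does not go with the higher number, as compound 3 also carries one, although the step from the other stereoisomer stays within the scatter (a 1.8-fold higher number from compound 1 to compound 4 (0.26 log units; within the scatter)). Nothing shown here gives a cause for this rise.

From the compounds shown here alone, it stays open whether an open-chain butyl group on the carbonyl carbon would read like the oxolan-3-yl ring, and how a ring carrying an amine would read.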